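Removing a Methyl from an Inactive Analogue

The compounds below may be only part of what the source reports. "The series", "measured", "known", "first", "only" and "open" are said of these compounds alone.

Two measured compounds frame this step. In a functional assay on HEK293 cells for antagonist activity at metabotropic glutamate receptor 5 (Rattus norvegicus) (on this read-out higher numbers stand for weaker inhibition and lower numbers for stronger inhibition), compound 1 `CCOc1ncc(C#Cc2cccc(C)c2)cn1` gives 21.1 nM. Compound 2 `Cc1ccc(C#Cc2ncccn2)cc1` in this assay gives only > 10000 nM, which is a limit of the assay rather than a number. Compound 2 therefore stands at the limit of > 10000 nM in this assay, at which 1 of the 2 values shown sits, while compound 1 stands at a measured value well inside the range of this assay. Compound 3 `C(#Cc1ncccn1)c1ccccc1` differs from compound 2 in one place: hydrogen in place of methyl on an aromatic carbon; in plain words, hydrogen in place of methyl on an aromatic carbon. Among the measured compounds shown here, no measured pair shows what removing this methyl does, so there is no guide to the direction of the step. Since compound 2 in this assay gives > 10000 nM, the expectation for compound 3 is that it also most likely reaches only the limit. The expected step is a step that the limit leaves unreadable from compound 2 to compound 3, nothing beyond the scatter. Compound 3 is estimated at 15000 nM, in a range from 4000 nM to 60000 nM.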

Compound 3, half-maximal inhibitory concentration: 195 nM
For compound 3 the middle estimate is 77-fold (1.89 log units) above the measured one, and the stated range ends above it.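

In this assay, the methyl on this aromatic carbon makes a large difference: hydrogen in its place brings an at least 51-fold lower number from compound 2 to compound 3 (1.70 log units; beyond the scatter), and the lower number means stronger inhibition. This position, para to a group of 8 heavy atoms, is therefore not indifferent to what it carries, and one carbon separates a compound with a measured value from one without. Going by these compounds, compound 2 gives > 10000 nM, a limit of the assay and not a number, and the full size of the step stays unknown.

On these data alone, whether a chlorine, a hydroxyl or an amine at this place would behave like the methyl or like the hydrogen remains open. A single pair also cannot tell whether the same change would have a similar effect on the core of compound 1.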